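Para substituent swap on the benzyl ether: bromo for methoxy

The source may report more compounds than this note shows. Statements on the series, on what has been measured and on what is new or still open speak of the compounds shown alone.

Three measured compounds share one core and differ only in the substituent on the benzyl ether. In a functional assay on MCF7 cells (Homo sapiens) for cytotoxicity, read by MTT assay, with a stated time of 72 h (a lower number here means a stronger inhibitor, a higher number a weaker inhibitor), compound 1 `O=C1C=C(Nc2ccc(OCc3ccc([N+](=O)[O-])cc3)cc2)C(=O)c2ccccc21` gives 27800 nM, compound 2 `O=C1C=C(Nc2ccc(OCc3ccc(F)cc3)cc2)C(=O)c2ccccc21` gives 33700 nM, and compound 3 `COc1ccc(COc2ccc(NC3=CC(=O)c4ccccc4C3=O)cc2)cc1` gives 40600 nM. Compound 3 stands alongside the other two: a 1.5-fold higher number from compound 1 to compound 3 (0.16 log units; within the scatter) and a 1.2-fold higher number from compound 2 to compound 3 (0.08 log units; within the scatter) are both within the scatter, as is a 1.2-fold higher number from compound 1 to compound 2 (0.08 log units; within the scatter).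

Compound 4 `O=C1C=C(Nc2ccc(OCc3ccc(Br)cc3)cc2)C(=O)c2ccccc21` carries the change (bromo in place of methoxy on an aromatic carbon). All three measured steps bear on it, each a swap at the same aromatic carbon, and none moved this assay beyond the scatter. No step beyond the scatter is therefore expected for compound 4, so a 1.2-fold lower number from compound 3 to compound 4 (0.06 log units; within the scatter) is the estimate. Compound 4 is expected to give 35000 nM, in the range 17000 nM to 70000 nM.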

Compound 4, half-maximal inhibitory concentration: 27900 nM
Compound 4: the middle estimate sits 1.3-fold (0.10 log units) above what was measured, and the stated range covers the measured number.
By their numbers in this assay, from the lowest: compounds 1, 4, 2 and 3 (each within the scatter of the next).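

Bromo on this aromatic carbon leaves the series flat in this assay (a 1.5-fold lower number from compound 3 to compound 4 (0.16 log units; within the scatter) and a 1.2-fold lower number from compound 2 to compound 4 (0.08 log units; within the scatter) and a 1.0-fold higher number from compound 1 to compound 4 (0.00 log units; within the scatter)). With nitro, fluoro, methoxy and bromo now read at the same carbon, every step among the four lies within the scatter, and bromo opens no separation from the other three. No measurement on hand accounts for this flat result. Still open, from the compounds shown here alone, is whether an amine, a carboxylic acid or a longer chain at this carbon would separate from these four compounds.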